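This account rests on a few compounds, and the source may have more. Where it says the series, first, only, none or still open, it means among the compounds named here.

Compound 1 `Cc1ccc2oc(/C=C/[S+](C)[O-])cc(=O)c2c1` carries a methyl on the aromatic carbon of its core. In a functional assay on A549 cells (Homo sapiens) for cytotoxicity, with a stated time of 48 h (a higher number here means a weaker inhibitor, a lower number a stronger inhibitor), compound 1 gives 1700 nM, which puts it second highest of the three numbers recorded. Compound 2 `CC(C)C(=O)Oc1ccc2oc(/C=C/[S+](C)[O-])cc(=O)c2c1` gives 2400 nM, and compound 3 `CC(C)COc1ccc2oc(/C=C/[S+](C)[O-])cc(=O)c2c1` gives 1100 nM; the step of a 1.4-fold higher number from compound 1 to compound 2 (0.15 log units; within the scatter) and the step of a 1.5-fold lower number from compound 1 to compound 3 (0.19 log units; within the scatter) both stay within the scatter, so no order can be claimed among these three compounds from the methyl side. Within the data shown here, only the step of a 2.2-fold lower number from compound 2 to compound 3 (0.34 log units; beyond the scatter) reaches beyond the scatter.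

Compound 4 `C[S+]([O-])/C=C/c1cc(=O)c2cc(OC(=O)C(C)(C)C)ccc2o1` has not yet been measured in this assay. It differs from compound 1 by ((tert-butyl)carbonyl)oxy in place of methyl on an aromatic carbon. The step that bears most directly on it is the change from compound 1 to compound 2, where an ester replaced the methyl in the same place and the number moved by a 1.4-fold higher number from compound 1 to compound 2 (0.15 log units; within the scatter). The change to compound 4 is of the same kind, with one more carbon in the acyl group. He therefore expects a step of about a 1.5-fold higher number from compound 1 to compound 4 (0.17 log units; within the scatter), that is, no movement beyond the scatter, in the direction of a slightly higher number. For compound 4 he estimates 2500 nM, with a range from 1200 nM to 5000 nM.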

Compound 4, half-maximal inhibitory concentration: 1600 nM
For compound 4 the middle estimate is 1.6-fold (0.19 log units) above the measured one, within the range that was stated.
By their numbers in this assay, from the lowest: compounds 3, 4, 1 and 2 (each within the scatter of the next, the first and the last beyond it).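

In this assay, the ((tert-butyl)carbonyl)oxy group, with 7 heavy atoms against the 1 of the methyl it replaces on the aromatic carbon, stays within the scatter of the methyl (a 1.1-fold lower number from compound 1 to compound 4 (0.03 log units; within the scatter)), so compounds 2 and 4 now give two esters at this place that cannot be told from compound 1. The added methyl on the saturated chain carbon bound to the carbonyl carbon cannot be read as an effect either (a 1.5-fold lower number from compound 2 to compound 4 (0.18 log units; within the scatter)). The earlier step beyond the scatter (a 2.2-fold lower number from compound 2 to compound 3 (0.34 log units; beyond the scatter)) therefore does not hold as a general gap between ester and ether, since compound 4 goes against it and stays within the scatter of the isobutyl ether (a 1.5-fold higher number from compound 3 to compound 4 (0.16 log units; within the scatter)).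

No evidence is at hand that bears on these numbers. The compounds shown leave open whether an amine or a carboxylic acid on this aromatic carbon, or a longer chain on the oxygen, would move the number beyond the scatter of compound 1.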